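Piperidin-4-yl against (pyrrolidin-3-yl)oxy on an aromatic carbon

A few compounds are considered here, and "the series" means these few. Any claim that something is new, unique, unknown or untested is made for them only; others in the source may bear on it.

Measured in an assay on isolated protein for inhibition of Myeloperoxidase (Homo sapiens), with a stated time of 10 min; on this read-out higher numbers stand for weaker inhibition and lower numbers for stronger inhibition:
compound 1 `Nc1cc(Cc2ccn(Cc3cccc(Oc4ccccc4)c3)n2)c2nn[nH]c2n1` gives 44 nM
compound 2 `Nc1cc(Cc2ccn(Cc3cccc(Oc4cccc5c4CNC5)c3)n2)c2nn[nH]c2n1` gives 26 nM
compound 3 `Nc1cc(Cc2ccn(Cc3cccc(C4CCNCC4)c3)n2)c2nn[nH]c2n1` gives 100 nM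

Compound 3 holds the highest of the three numbers: the nearest is compound 1, a 2.3-fold higher number from compound 1 to compound 3 (0.36 log units; beyond the scatter); the furthest is compound 2, a 3.8-fold higher number from compound 2 to compound 3 (0.59 log units; beyond the scatter). Compound 4 `Nc1cc(Cc2ccn(Cc3cccc(O[C@H]4CCNC4)c3)n2)c2nn[nH]c2n1` differs from compound 3 by (pyrrolidin-3-yl)oxy in place of piperidin-4-yl on an aromatic carbon. Both measured steps out of compound 3 bear on this change, since each exchanged the piperidin-4-yl for an oxygen-linked group and both ended at a lower number, the step from compound 2 being the larger. A modest step toward a lower number in this assay is therefore expected, a 1.8-fold lower number from compound 3 to compound 4 (0.26 log units; within the scatter). Compound 4 is estimated at 55 nM, with a range from 22 nM to 140 nM.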

Compound 4, half-maximal inhibitory concentration: 46 nM
The estimate for compound 4 lay 1.2-fold (0.08 log units) above the measured number; the range from low to high includes it.
By their numbers in this assay, from the lowest: compounds 2, 1 and 4 (each within the scatter of the next); then compound 3.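

With the heavy-atom count of the group unchanged, (pyrrolidin-3-yl)oxy in place of piperidin-4-yl still moves the number in this assay (a 2.2-fold lower number from compound 3 to compound 4 (0.34 log units; beyond the scatter)). An aromatic ring on the oxygen is not needed to stay level with the aryl ethers: pyrrolidin-3-yl in place of phenyl (a 1.0-fold higher number from compound 1 to compound 4 (0.02 log units; within the scatter)) and in place of the larger bicyclic group (a 1.8-fold higher number from compound 2 to compound 4 (0.25 log units; within the scatter)) both stay within the scatter. No supporting data explain these steps. Open: whether the opposite configuration at the defined stereocentre keeps this level, and whether an azetidin-3-yloxy group or a 2-aminoethoxy chain does.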